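The source may report more compounds than this note shows. Statements on the series, on what has been measured and on what is new or still open speak of the compounds shown alone.

In a functional assay on MGC-803 cells (Homo sapiens) for cytotoxicity, read by MTT assay, with a stated time of 72 h (a higher number here means a weaker inhibitor, a lower number a stronger inhibitor), compound 1 `O=C1C(=Cc2ccc(F)cc2)C(=O)N(c2ccc(Cl)cc2)N1c1ccc(Cl)cc1` gives 26000 nM. Its two measured relatives sit within the usual scatter of it: compound 2 `O=C1C(=Cc2ccc(Cl)cc2)C(=O)N(c2ccc(Cl)cc2)N1c1ccc(Cl)cc1` gives 32600 nM and compound 3 `COc1cccc(C=C2C(=O)N(c3ccc(Cl)cc3)N(c3ccc(Cl)cc3)C2=O)c1O` gives 24300 nM. So compound 1 has no clear rank among the three.

Compound 4 `COc1cccc(C=C2C(=O)N(c3ccc(Cl)cc3)N(c3ccc(Cl)cc3)C2=O)c1` has not been measured yet. It keeps the core of compound 1 and differs in one group, with 3-methoxyphenyl in place of 4-fluorophenyl on a double-bonded chain carbon bound to a double-bonded ring carbon.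

Within the data shown here, two measured steps bear on this change. Putting chloro in place of fluoro on an aromatic carbon gave a 1.3-fold higher number from compound 1 to compound 2 (0.10 log units; within the scatter). The closer guide is the swap at the same carbon to 2-hydroxy-3-methoxyphenyl, which also carries a methoxy and gave a 1.1-fold lower number from compound 1 to compound 3 (0.03 log units; within the scatter). Both steps are small and within the scatter, so no step beyond the scatter is expected in this assay.

The expected step is a 1.0-fold lower number from compound 1 to compound 4 (0.02 log units; within the scatter).

For compound 4 the estimated value is 25000 nM, with an expected range from 13000 nM to 50000 nM.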

Compound 4, half-maximal inhibitory concentration: 26600 nM
Compound 4: the middle estimate sits 1.1-fold (0.03 log units) below what was measured; low and high end bracket the measured number.
By their numbers in this assay, from the lowest: compounds 3, 1, 4 and 2 (each within the scatter of the next).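

In this assay, the hydroxy group of compound 3 can now be judged on its own: hydrogen in its place on an aromatic carbon gave a 1.1-fold higher number from compound 3 to compound 4 (0.04 log units; within the scatter). The 3-methoxyphenyl group, compared with the two halogen-bearing phenyl groups at the same double-bonded chain carbon, gave a 1.0-fold higher number from compound 1 to compound 4 (0.01 log units; within the scatter) and a 1.2-fold lower number from compound 2 to compound 4 (0.09 log units; within the scatter), so all four substituted phenyl groups shown at this carbon lie within the scatter of one another. No outside evidence is at hand to explain this flat result.

The compounds shown leave open whether a different kind of group at this carbon, such as a phenyl ring bearing an amine or a carboxylic acid, would move the number beyond the scatter. On these data alone, whether changes elsewhere on the shared core would do so also remains open.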